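Notes on the step from compound 3 to compound 4

The source may hold more compounds than are shown below. What is called first, only, known or untested is meant among the compounds shown, and "the series" means these compounds.

Values in an ADME assay on microsomes from liver (Rattus norvegicus) for metabolic stability, read by LC-MS, with a stated time of 10 min, tested at 0.5 uM (on this read-out higher numbers stand for a more stable compound and lower numbers for a less stable compound), so far:
compound 1 `c1ccc2c(c1)CN[C@H](CN(CCCN1CCNCC1)[C@H]1CCCc3cccnc31)C2` gives 88%
compound 2 `c1ccc2c(c1)CN[C@@H](CN(CC[C@@H]1CCCNC1)[C@H]1CCCc3cccnc31)C2` gives 28%
compound 3 `c1cnc2c(c1)CCC[C@@H]2N(CCCN1CCNCC1)Cc1cc2ccccc2cn1` gives 59%

Compound 3 stands second highest of the three, with compound 1 higher and compound 2 lower, both gaps beyond the scatter. Among the compounds with values here, compound 4 `c1cnc2c(c1)CN[C@@H](CN(CCCN1CCNCC1)[C@H]1CCCc3cccnc31)C2` departs from compound 3 by a group of 10 heavy atoms (8 carbon, 2 nitrogen; one six-membered non-aromatic ring with 1 hetero atom, one six-membered aromatic ring with 1 hetero atom) in place of a group of 10 heavy atoms (9 carbon, 1 nitrogen; one six-membered aromatic ring of carbon only, one six-membered aromatic ring with 1 hetero atom), on a saturated chain carbon bound to an amine nitrogen as its single change. Within the data shown here, the one measured step bearing on this is a number 29 percentage points lower from compound 1 to compound 3 (beyond the scatter) in this assay with isoquinolin-3-yl in place of 1,2,3,4-tetrahydroisoquinolin-3-yl. That step is modest but beyond the scatter. The group entering compound 4 has a six-membered non-aromatic ring with 1 hetero atom, as does the group in compound 1 at 88% in this read-out. Among the measured compounds shown here, no measured compound carries the entering group itself, so how closely compound 4 will track compound 1 is open. An upward step somewhat smaller than the measured one is expected, estimated as a number 21 percentage points higher from compound 3 to compound 4 (beyond the scatter) and so beyond the scatter. The estimate for compound 4 is 80% with an expected range of 62% to 95% on repeat measurement.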

Compound 4, percent of the compound remaining: 79%
Beside the measured number, compound 4's estimate is 1 percentage points above it; measured number inside the range.
By their numbers in this assay, from the lowest: compound 2; then compound 3; then compounds 4 and 1 (each within the scatter of the next).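

With the non-aromatic ring back in the entering group, this assay gives a number 20 percentage points higher from compound 3 to compound 4 (beyond the scatter), so the loss seen on going to isoquinolin-3-yl is reversed in a second compound; this pattern covers compounds 1, 3 and 4 only, and compound 2, which departs from them elsewhere, cannot be read against it. The step of a number 9 percentage points lower from compound 1 to compound 4 (within the scatter) shows that a six-membered aromatic ring with 1 hetero atom in place of one of carbon only leaves no readable change at this position. No measured information explains either step.

Open, on these data alone, is whether a methyl or acetyl group on the nitrogen of the non-aromatic ring would keep this standing. Also open, as far as these compounds go, is how the opposite configuration at the defined stereocentre of the entering group would read.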